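This account rests on a few compounds, and the source may have more. Where it says the series, first, only, none or still open, it means among the compounds named here.

In an ADME assay on microsomes from liver (Homo sapiens) for metabolic stability, read by LC-MS, using NADPH, with stated times of 5 min and 30 min, tested at 1 uM (a lower number here means slower removal, a higher number faster removal of the compound), compound 1 `O=C1c2ccccc2CN1c1cnc(NCc2c(F)ccc3c2CCO3)n2cnnc12` gives 13 mL.min-1.g-1 and compound 2 `Fc1ccc2c(c1CNc1ncc(Oc3ccccc3)c3nncn13)CCO2` gives 18 mL.min-1.g-1. For compound 3 `CN(C(=O)c1ccccc1)c1cnc(NCc2c(F)ccc3c2CCO3)n2cnnc12`, the assay reports only a limit, > 300 mL.min-1.g-1. Compound 4 `Fc1ccc2c(c1CNc1ncc(Nc3ccccc3)c3nncn13)CCO2` has anilino in place of benzoyl(methyl)amino on an aromatic carbon. Among the measured compounds, only compound 3 carries benzoyl(methyl)amino, and two large steps lead to it: an at least 23-fold higher number from compound 1 to compound 3 (1.36 log units; beyond the scatter) and an at least 16-fold higher number from compound 2 to compound 3 (1.22 log units; beyond the scatter). The step between the other two, a 1.4-fold higher number from compound 1 to compound 2 (0.14 log units; within the scatter), lies within the scatter. On this evidence, a large step towards slower removal is expected, an at least 12-fold lower number from compound 3 to compound 4 (1.07 log units; beyond the scatter). Compound 4 is estimated at 25 mL.min-1.g-1, with an expected range of 8 mL.min-1.g-1 to 80 mL.min-1.g-1.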

Compound 4, intrinsic clearance in microsomes: 20 mL.min-1.g-1
Compound 4: the middle estimate sits 1.3-fold (0.10 log units) above what was measured, and the stated range covers the measured number.
By their numbers in this assay, from the lowest: compounds 1, 2 and 4 (each within the scatter of the next). At a limit, above all of these: compound 3.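

In this assay, swapping benzoyl(methyl)amino for anilino at this position gives an at least 15-fold lower number from compound 3 to compound 4 (1.17 log units; beyond the scatter), so attachment through nitrogen does not by itself go with a high number. Compound 4 also matches the earlier low compounds, with a 1.1-fold higher number from compound 2 to compound 4 (0.05 log units; within the scatter) and a 1.5-fold higher number from compound 1 to compound 4 (0.19 log units; within the scatter), so three different groups here give values within the scatter of one another. The value of compound 3 is a limit, so that first step has no upper end: the limit of > 300 mL.min-1.g-1 in this assay, at which 1 of the 4 values shown sits.

The compounds shown leave open which part of benzoyl(methyl)amino goes with the high number. They also leave open whether a group without an aromatic ring, such as morpholine or a short alkyl chain, would give a similarly low number.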